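The source may report more compounds than this note shows. Statements on the series, on what has been measured and on what is new or still open speak of the compounds shown alone.

Measured compounds:
compound 1 `Cc1nc(S(C)(=O)=O)ccc1Oc1ncnc(OC2CCN(C(=O)OC(C)C)CC2)c1F` — 21 nM
compound 2 `Cc1nc(S(C)(=O)=O)ccc1Oc1ncnc(OC2CCN(C(=O)OC3(C(F)(F)F)CCC3)CC2)c1F` — 14.3 nM
compound 3 `Cc1nc(S(C)(=O)=O)ccc1Oc1ncnc(OC2CCN(C(=O)SC(C)(C)C)CC2)c1F` — 4.83 nM

Values are from a functional assay on isolated protein for inhibition of Glucose-dependent insulinotropic receptor (Homo sapiens), read by HTRF and cAMP accumulation; on this read-out higher numbers stand for an effect only at larger amounts of compound and lower numbers for an effect already at smaller amounts. Compound 3 gives the lowest number of the three, its steps to both others lying beyond the scatter: a 4.3-fold lower number from compound 1 to compound 3 (0.64 log units; beyond the scatter) and a 3.0-fold lower number from compound 2 to compound 3 (0.47 log units; beyond the scatter), whereas a 1.5-fold lower number from compound 1 to compound 2 (0.17 log units; within the scatter). Compound 4 `Cc1nc(S(C)(=O)=O)ccc1Oc1ncnc(OC2CCN(C(=O)C3(C)CC3)CC2)c1F` differs from compound 3 only at the carbonyl substituent: 1-methylcyclopropyl in place of (tert-butyl)sulfanyl on a carbonyl carbon. The two steps that bear on this position are both modest and both favour compound 3. Within the data shown here, no measured step covers a carbon substituent at this carbonyl, so the change is untested here; a small movement back toward the range of compound 1 and compound 2 is expected rather than a further gain. For compound 4 the expected step is a 2.1-fold higher number from compound 3 to compound 4 (0.32 log units; beyond the scatter). Compound 4 is estimated at 10 nM, range 4 nM to 30 nM.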

Compound 4, half-maximal effective concentration: 761 nM
Compound 4: middle estimate off by 76-fold (1.88 log units), on the low side; measured number above the stated range.
By their numbers in this assay, from the lowest: compound 3; then compounds 2 and 1 (each within the scatter of the next); then compound 4.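

Among these compounds, on a carbonyl carbon bonded to an amide-type nitrogen in a ring, the oxygen- and sulfur-linked groups of the earlier compounds gave modest steps at most, but 1-methylcyclopropyl, the only carbon-linked group, gives a large one in this assay (a 160-fold higher number from compound 3 to compound 4 (2.20 log units; beyond the scatter)). The rise also holds against both oxygen-linked compounds (a 53-fold higher number from compound 2 to compound 4 (1.73 log units; beyond the scatter); a 36-fold higher number from compound 1 to compound 4 (1.56 log units; beyond the scatter)), so it is not specific to replacing (tert-butyl)sulfanyl. No measurement here accounts for it.

With one carbon-linked example, the linking atom cannot be separated from 1-methylcyclopropyl itself. A tert-butyl or dimethylamino group on this carbonyl carbon would bear on that question.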